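The source may hold more compounds than are shown below. What is called first, only, known or untested is meant among the compounds shown, and "the series" means these compounds.

In a functional assay on DU-145 cells (Homo sapiens) for cytotoxicity, read by CCK-8 assay and cell counting, with a stated time of 2 days (a lower number here means a stronger inhibitor, a higher number a weaker inhibitor), compound 2 `Oc1ccc(-c2cc(-c3cccc(Cl)c3)nc(-c3cccs3)c2)cc1` gives 5740 nM. For the measured compounds named here, the only other compound measured here, compound 1 `Oc1ccc(-c2cc(-c3cccs3)nc(-c3ccccc3Cl)c2)cc1`, gives 4190 nM in this assay. Going by the values given here, the one measured step, a 1.4-fold higher number from compound 1 to compound 2 (0.14 log units; within the scatter), is within the scatter, so compound 2 and compound 1 give numbers that cannot be told apart, and compound 2 has no other neighbour to stand against.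

Compound 3 `Oc1ccc(-c2cc(-c3ccccc3)nc(-c3cccc(Cl)c3)c2)cc1` differs from compound 2 in one place: phenyl in place of thiophen-2-yl on an aromatic carbon. Among the compounds with values here, no measured step here swaps a thiophen-2-yl for a phenyl, so the only guidance is that the single change so far, moving the chlorine on a phenyl group, stayed within the scatter. On that basis compound 3 is expected to stay close to compound 2, with the step of a 1.1-fold lower number from compound 2 to compound 3 (0.06 log units; within the scatter) expected to be small and of uncertain direction. The value for compound 3 in this assay is therefore estimated at 5000 nM, with a range from 2000 nM to 13000 nM.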

Compound 3, half-maximal inhibitory concentration: 5360 nM
For compound 3 the middle estimate is 1.1-fold (0.03 log units) below the measured one; the range from low to high includes it.
By their numbers in this assay, from the lowest: compounds 1, 3 and 2 (each within the scatter of the next).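

For the compounds shown here, the step of a 1.1-fold lower number from compound 2 to compound 3 (0.03 log units; within the scatter) is the first measured change of the ring itself, not just of where a chlorine sits. On this aromatic carbon next to the ring nitrogen, a five-membered aromatic ring holding sulfur and a six-membered aromatic ring of carbon only give numbers that cannot be told apart in this assay. So, for this one pair, the size of the ring and the presence of sulfur make no readable difference. No measurement shown here explains why the two rings read alike.

From the compounds shown here alone, both groups compared at this position are aromatic rings, so it remains open how an amine, a carboxylic acid or a longer alkyl chain would read there. Going by these compounds, it is also open whether phenyl and thiophen-2-yl would still match if the 3-chlorophenyl or 4-hydroxyphenyl group were replaced.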